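Thiosemicarbazone series: hydroxyphenyl to thiophenyl swap

The compounds below may be only part of what the source reports. "The series", "measured", "known", "first", "only" and "open" are said of these compounds alone.

All four compounds carry the same core and differ only at the arylidene end of the thiosemicarbazone. Going by the values given here, compound 2, `CC1=CC[C@H](C(C)(C)NC(=S)N/N=C/c2ccccc2O)CC1`, is the only member with a number in a functional assay on OVCAR-3 cells (Homo sapiens) for inhibition, read by sulforhodamine B assay, with a stated time of 48 h (a higher number here means a weaker inhibitor of growth, a lower number a stronger inhibitor of growth), where compound 2 gives 5500 nM. Compound 1, `CC1=CC[C@H](C(C)(C)N=C=S)CC1`, the isothiocyanate without any arylidene group, sits at the limit of the assay: in this assay compound 1 gives > 100000 nM, a limit and not a number. Compound 3, `CC1=CC[C@H](C(C)(C)NC(=S)N/N=C/c2cccc([N+](=O)[O-])c2)CC1`, also returns only a limit; in this assay compound 3 gives > 100000 nM. The series is therefore dominated by the limit of > 100000 nM in this assay, at which 2 of the 3 values shown sit, and compound 2 stands alone as the single measurable point.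

Compound 4, `CC1=CC[C@H](C(C)(C)NC(=S)N/N=C/c2cccs2)CC1`, differs from compound 2 by thiophen-2-yl in place of 2-hydroxyphenyl on a carbon with a double bond to nitrogen. Among the compounds with values here, no step between two measured compounds is available to calibrate this change; the thiophen-2-yl group removes the single hydrogen-bond donor that the 2-hydroxyphenyl group brought, while the acceptor count stays. The expected direction is a loss of potency beyond the usual scatter, with a real chance that compound 4 again reaches only the limit. The estimated step is a 3.6-fold higher number from compound 2 to compound 4 (0.56 log units; beyond the scatter). Compound 4 is expected near 20000 nM, within a range from 5000 nM to 100000 nM.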

Compound 4, concentration for 50% growth inhibition: 13100 nM
The estimate for compound 4 lay 1.5-fold (0.18 log units) above the measured number; measured number inside the range.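

Thiophen-2-yl in place of 2-hydroxyphenyl on a carbon with a double bond to nitrogen costs only a modest step in this assay, a 2.4-fold higher number from compound 2 to compound 4 (0.38 log units; beyond the scatter), so the series now has a second measurable point. Thiophen-2-yl carries no hydrogen-bond donor, so a donor on the aromatic ring at this position is not required for a measurable number, although the step lies beyond the usual scatter. Even so, the limit keeps its weight in the series: the limit of > 100000 nM in this assay, at which 2 of the 4 values shown sit.

The aromatic ring at this position is not settled by these results, as compound 3, which also has no hydrogen-bond donor on that ring, gives > 100000 nM in this assay, a limit and not a number. Open too, going by these compounds, is how furan-2-yl, pyridin-2-yl or 2-methoxyphenyl would fare at this position, and whether the hydroxyl of compound 2 adds anything of its own beyond the phenyl ring that carries it.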